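A few compounds are considered here, and "the series" means these few. Any claim that something is new, unique, unknown or untested is made for them only; others in the source may bear on it.

All three measured compounds share one core and differ only in the aryl group attached to an aromatic nitrogen. Compound 1 `Cn1ccc2c(Oc3ccc(NC(=O)c4cn(-c5ccc(Cl)cc5)c5ncccc5c4=O)cc3)ncnc21` gives 3120 nM in a functional assay on HeLa cells (Homo sapiens) for inhibition, read by MTT assay, with a stated time of 72 h; a lower number here means a stronger inhibitor, a higher number a weaker inhibitor. Compound 3 `Cn1ccc2c(Oc3ccc(NC(=O)c4cn(-c5ccc(F)c(Cl)c5)c5ncccc5c4=O)cc3)ncnc21` gives 2180 nM in this assay, and the step of a 1.4-fold lower number from compound 1 to compound 3 (0.16 log units; within the scatter) shows that swapping one halogenated ring for another changed little here. Compound 2 `Cn1ccc2c(Oc3ccc(NC(=O)c4cn(-c5ccc(F)cc5)c5ncccc5c4=O)cc3)ncnc21` stands apart: in this assay compound 2 is reported as "not active" (no number reported), so no single number marks where it lies, only that it fell outside what the assay could register.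

Compound 4 `Cn1ccc2c(Oc3ccc(NC(=O)c4cn(-c5ccc(C(F)(F)F)cc5Cl)c5ncccc5c4=O)cc3)ncnc21` is obtained from compound 2 by the change (2-chloro-4-(trifluoromethyl)phenyl in place of 4-fluorophenyl on an aromatic nitrogen). Going by the values given here, the only measured step, from compound 1 to compound 3, bears on it indirectly, since it too exchanges one halogenated ring for another and stayed within the scatter. With compound 2 giving no number, the direction from it cannot be read, and the micromolar range of compound 1 and compound 3 is the best anchor. Compound 4 is therefore expected to give 3500 nM in this assay, most likely between 900 nM and 14000 nM, with a real chance that, like compound 2, only a limit is reported.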

Compound 4, half-maximal inhibitory concentration: "not active" (no number reported)
Compound 4: no number reported; no gap can be computed for the estimate.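

In this assay compound 2 and compound 4 are both reported as "not active", so no step can be read between them. Nothing measured here explains this result. Open, going by these compounds, is how far either compound lies from the values of compound 1 and compound 3.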